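Lengthening the selenium-bearing chain of compound 2

A few compounds are considered here, and "the series" means these few. Any claim that something is new, unique, unknown or untested is made for them only; others in the source may bear on it.

For the measured compounds named here, in a functional assay on A549 cells (Homo sapiens) for inhibition, read by MTT assay, with a stated time of 48 h (on this read-out lower numbers stand for stronger inhibition and higher numbers for weaker inhibition), compound 2 (`COc1ccc(N(C)c2nc(C)nc3ccccc23)cc1OCC[Se]C#N`) gives 13 nM, the lower of the two numbers so far, and compound 1 (`COc1ccc(N(C)c2nc(C)nc3ccccc23)cc1OCCC[Se]C#N`) gives 382 nM. Compound 3 (`COc1ccc(N(C)c2nc(C)nc3ccccc23)cc1OCCCC[Se]C#N`) differs from compound 2 by a group of 5 heavy atoms (3 carbon, 1 nitrogen, 1 selenium; no ring) in place of a group of 3 heavy atoms (1 carbon, 1 nitrogen, 1 selenium; no ring), on a saturated chain carbon, two bonds along the chain from an oxygen on an aromatic ring, on a saturated chain carbon, two bonds along the chain from an oxygen on an aromatic ring. Going by the values given here, the only step bearing on this is a 29-fold lower number from compound 1 to compound 2 (1.47 log units; beyond the scatter), large and beyond the scatter, and here the group grows instead of shrinking. A rise of similar size is therefore expected, though one step is thin evidence. The expected change is a 27-fold higher number from compound 2 to compound 3 (1.43 log units; beyond the scatter). Compound 3 is estimated at 350 nM, within a range of 70 nM to 1800 nM.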

Compound 3, half-maximal inhibitory concentration: 1200 nM
The estimate for compound 3 lay 3.4-fold (0.54 log units) below the measured number; measured number inside the range.
By their numbers in this assay, from the lowest: compound 2; then compound 1; then compound 3.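

At this position, on a saturated chain carbon, two bonds along the chain from an oxygen on an aromatic ring, further growth of the selenium-bearing chain raises the number again, with a 92-fold higher number from compound 2 to compound 3 (1.97 log units; beyond the scatter) as the full span of the series. The last lengthening adds less than the first, with a 3.1-fold higher number from compound 1 to compound 3 (0.50 log units; beyond the scatter) against the earlier large step, so the number climbs steeply and then more gently, and none of the three compounds goes against this order.

Open, from the compounds shown here alone, is whether a longer chain continues the rise, and whether an amine in place of the selenium and nitrile end keeps the low number of compound 2. Nothing available explains the size of either step.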